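The source may hold more compounds than are shown below. What is called first, only, known or untested is meant among the compounds shown, and "the series" means these compounds.

In a functional assay on CWR22R cells (Homo sapiens) for antiproliferative activity, read by propidium iodide staining, with a stated time of 96 h (a higher number here means a weaker inhibitor, a lower number a stronger inhibitor), compound 1 `CC(O)(CSc1ccc(S(F)(F)(F)(F)F)cc1)C(=O)Nc1ccc([N+](=O)[O-])cc1C(F)(F)F` gives 13100 nM, compound 2 `CC(O)(CSc1ccc(OC(F)(F)F)cc1)C(=O)Nc1ccc(S(F)(F)(F)(F)F)cc1` gives 14900 nM and compound 3 `CC(O)(COc1ccc(S(F)(F)(F)(F)F)cc1)C(=O)Nc1cccc(S(F)(F)(F)(F)F)c1` gives 10200 nM. These three numbers all lie within the usual scatter of repeated measurements, so compound 3 stands level with the other two and no ranking can be drawn among them.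

Compound 4 `CC(O)(COc1ccc(C#N)cc1)C(=O)Nc1cccc(S(F)(F)(F)(F)F)c1` differs from compound 3 in one place: a group of 2 heavy atoms (1 carbon, 1 nitrogen; no ring) in place of a group of 6 heavy atoms (5 fluorine, 1 sulfur; no ring), on an aromatic carbon. A cyano group enters on an aromatic carbon, para to a large group, in place of a group of 6 heavy atoms (5 fluorine, 1 sulfur).

Within the data shown here, no two measured compounds differ in one place only, so the data give no direct size for such a step in this assay. Among the measured compounds shown here, with compound 1 at 13100 nM and compound 2 at 14900 nM, the only guide is this narrow band, so no step beyond the scatter is expected. The expected change is a 1.4-fold higher number from compound 3 to compound 4 (0.14 log units; within the scatter). For compound 4 the estimated value is 14000 nM, with an expected range of 6000 nM to 35000 nM.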

Compound 4, half-maximal inhibitory concentration: 32500 nM
For compound 4 the middle estimate is 2.3-fold (0.37 log units) below the measured one; low and high end bracket the measured number.
By their numbers in this assay, from the lowest: compounds 3, 1 and 2 (each within the scatter of the next); then compound 4.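

Among these compounds, this is the first single change that can be read in this assay: on an aromatic carbon, para to a large group, cyano replaces the group of 6 heavy atoms (5 fluorine, 1 sulfur), giving a 3.2-fold higher number from compound 3 to compound 4 (0.50 log units; beyond the scatter). The position is therefore not indifferent to what sits on it, and of these two groups cyano gives the weaker inhibitor, though the step is modest. Nothing shown here bears on why the number rises.

Among the compounds shown here, with only two groups compared at this position, it remains open whether an amine or a methoxy group would fall nearer compound 3 or compound 4. On these data alone, it also remains open whether the same swap would give a step of similar size with the sulfur link of compound 1 in the chain.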